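An acylated carbamoyl returns to the amine nitrogen

This account rests on a few compounds, and the source may have more. Where it says the series, first, only, none or still open, it means among the compounds named here.

Of the compounds shown here, three sharing one core have been tested in a functional assay on CCRF-CEM cells (Homo sapiens); on this read-out higher numbers stand for lower toxicity in this test and lower numbers for higher toxicity in this test. Compound 1 `CCNC(=O)NC1=CS(=O)(=O)O[C@@]12[C@@H](CO[Si](C)(C)C(C)(C)C)O[C@@H](n1cc(C)c(=O)n(C)c1=O)[C@@H]2O[Si](C)(C)C(C)(C)C` gives 4260 nM. Compound 2 `COC(=O)CC(=O)NC1=CS(=O)(=O)O[C@@]12[C@@H](CO[Si](C)(C)C(C)(C)C)O[C@@H](n1cc(C)c(=O)n(C)c1=O)[C@@H]2O[Si](C)(C)C(C)(C)C` gives 29700 nM. For compound 3 `COC(=O)CCNC1=CS(=O)(=O)O[C@@]12[C@@H](CO[Si](C)(C)C(C)(C)C)O[C@@H](n1cc(C)c(=O)n(C)c1=O)[C@@H]2O[Si](C)(C)C(C)(C)C` only a limit of the assay is known, > 250000 nM, so it stands at the upper edge of the numbers shown. Compound 4 `C=C(C)C(=O)NC(=O)NC1=CS(=O)(=O)O[C@@]12[C@@H](CO[Si](C)(C)C(C)(C)C)O[C@@H](n1cc(C)c(=O)n(C)c1=O)[C@@H]2O[Si](C)(C)C(C)(C)C` differs from compound 3 by ((1-methylethenyl)carbonyl)carbamoyl in place of 2-(methoxycarbonyl)ethyl on an amine nitrogen. The most telling measured step is an at least 58-fold higher number from compound 1 to compound 3 (1.76 log units; beyond the scatter), which shows that putting 2-(methoxycarbonyl)ethyl in place of ethylcarbamoyl pushed the number far up; an at least 8.4-fold higher number from compound 2 to compound 3 (0.92 log units; beyond the scatter) points the same way. Bringing a carbamoyl back in compound 4 is therefore expected to reverse much of that, giving an at least 25-fold lower number from compound 3 to compound 4 (1.39 log units; beyond the scatter), an estimate of 10000 nM with a range from 2000 nM to 60000 nM.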

Compound 4, half-maximal cytotoxic concentration: 1200 nM
Beside the measured number, compound 4's estimate is 8.3-fold (0.92 log units) above it, and the stated range ends above it.
By their numbers in this assay, from the lowest: compound 4; then compound 1; then compound 2. At a limit, above all of these: compound 3.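

In this assay compound 3 is known only as a limit, > 250000 nM. Placing ((1-methylethenyl)carbonyl)carbamoyl on the amine nitrogen gives an at least 200-fold lower number from compound 3 to compound 4 (2.31 log units; beyond the scatter), and the comparison with the malonyl-type amide gives a 25-fold lower number from compound 2 to compound 4 (1.39 log units; beyond the scatter), so this change does more than restore part of the lost toxicity. On the amide-type nitrogen, (1-methylethenyl)carbonyl in place of ethyl gives a 3.6-fold lower number from compound 1 to compound 4 (0.55 log units; beyond the scatter), making compound 4 the lowest of the four. Still open, as far as these compounds go, is whether the carbon-carbon double bond matters, which a saturated 2-methylpropanoyl group on that nitrogen would test.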